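Thiophene in Place of Phenyl, Tried a Second Time

The source may report more compounds than this note shows. Statements on the series, on what has been measured and on what is new or still open speak of the compounds shown alone.

Compound 1 `Oc1ccc(-c2cc(-c3ccccc3)cc(-c3ccccc3)n2)cc1` was tested in a functional assay on HCT-15 cells (Homo sapiens) for cytotoxicity, read by ELISA, with a stated time of 2 days (a lower number here means a stronger inhibitor, a higher number a weaker inhibitor), where compound 1 gives 3700 nM. Compound 2 `Oc1ccc(-c2cc(-c3ccccc3)cc(-c3cccs3)n2)cc1` differs from compound 1 in one place: thiophen-2-yl in place of phenyl on an aromatic carbon. That change produced a 3.4-fold higher number from compound 1 to compound 2 (0.53 log units; beyond the scatter). Compound 3 `Oc1cccc(-c2cc(-c3ccccc3)nc(-c3ccccc3)c2)c1` holds the same atoms as compound 1, joined differently; the difference between the two cores is not broken down here. In this assay compound 3 gives 18000 nM, a number beyond the scatter from compound 1, while compound 2, which gives 12500 nM, lies within the scatter of compound 3. Compound 4 `Oc1cccc(-c2cc(-c3ccccc3)nc(-c3cccs3)c2)c1` has not been measured. It is made from compound 3 by the same kind of change: thiophen-2-yl in place of phenyl on an aromatic carbon. The surroundings differ in one respect: in compound 2 the entering group sits meta to a 4-hydroxyphenyl group, in compound 4 meta to a 3-hydroxyphenyl group. Within the data shown here, only one measured example of this change exists, so the expectation rests on a single step. The expected step is a 3.1-fold higher number from compound 3 to compound 4 (0.49 log units; beyond the scatter), resting on a 3.4-fold higher number from compound 1 to compound 2 (0.53 log units; beyond the scatter). Compound 4 is therefore estimated to give 55000 nM, with a likely range from 15000 nM to 150000 nM. A number this weak could come back only as a limit.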

Compound 4, half-maximal inhibitory concentration: 14100 nM
Compound 4: middle estimate off by 3.9-fold (0.59 log units), on the high side; the measured number lies below the stated range.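

In this assay, putting thiophen-2-yl in place of phenyl on the core of compound 3 gives a 1.3-fold lower number from compound 3 to compound 4 (0.11 log units; within the scatter), so on this core the two groups cannot be told apart. The same swap had a clear effect on the core of compound 1, and the two results do not match: the same change on two cores in this assay, a 3.4-fold higher number (0.53 log units; beyond the scatter) from compound 1 to compound 2 and a 1.3-fold lower number (0.11 log units; within the scatter) from compound 3 to compound 4, 4.3-fold (0.63 log units) apart, beyond the scatter of two such steps This shows that, among these four compounds, the result of the swap on one core does not predict its result on the other, but with a single step on each core it does not show which difference between the cores matters or how other cores would respond.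

The compounds shown leave open whether another ring, such as furan-2-yl or pyridin-3-yl, would also depend on the core in this way. They also leave open how either core would respond if an amine or a carboxylic acid stood in place of the hydroxyl group.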